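A hydroxy group added to the stronger of two compounds

This account rests on a few compounds, and the source may have more. Where it says the series, first, only, none or still open, it means among the compounds named here.

In a functional assay on L1210 cells (Mus musculus) for antiproliferative activity, with a stated time of 4 h (a lower number here means a stronger inhibitor, a higher number a weaker inhibitor), compound 1 `O=C1CCc2c1c1c(c3c2[nH]c2ccccc23)C(=O)NC1=O` gives 58400 nM. Compound 2 `O=c1ccc(=O)c2c1c1[nH]c3ccccc3c1c1c(=O)[nH]c(=O)c21` gives 6800 nM, the lower of the two numbers, and this gap lies beyond the usual scatter. Compound 3 `O=c1ccc(=O)c2c1c1[nH]c3ccc(O)cc3c1c1c(=O)[nH]c(=O)c21` is not yet measured. It has hydroxy in place of hydrogen on an aromatic carbon of compound 2 (hydroxy in place of hydrogen on an aromatic carbon). Among the measured compounds shown here, no measured pair shows this change, so only a modest gain in this assay is expected, with little certainty. The estimated change is a 2.3-fold lower number from compound 2 to compound 3 (0.36 log units; beyond the scatter), a move toward a lower number. Compound 3 is estimated at 3000 nM, with an expected range from 700 nM to 12000 nM.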

Compound 3, half-maximal inhibitory concentration: 8400 nM
The estimate for compound 3 lay 2.8-fold (0.45 log units) below the measured number; measured number inside the range.
By their numbers in this assay, from the lowest: compounds 2 and 3 (each within the scatter of the next); then compound 1.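

In this assay, hydroxy in place of hydrogen on this aromatic carbon, meta to a fused ring and para to a fused ring, gives a 1.2-fold higher number from compound 2 to compound 3 (0.09 log units; within the scatter). The two compounds therefore cannot be told apart in this assay, so this position accepts a hydroxy group without a change beyond the scatter. No measurement at hand explains this result. Still open, from the compounds shown here alone, is how a different group at this carbon, such as an amine, a methoxy group or a carboxylic acid, would read. Also open, going by these compounds, is whether hydroxy on another carbon of the shared core would give the same result.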